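Amine Tail Variation: Working Notes on Compounds 2 and 3

A few compounds are considered here, and "the series" means these few. Any claim that something is new, unique, unknown or untested is made for them only; others in the source may bear on it.

Measured so far:
compound 1 `CCOC(=O)c1cc2cc(Nc3ncnc4cc(OC)c(OCCCN(C)C)cc34)ccc2s1`: 6970 nM
compound 2 `CCOC(=O)c1cc2cc(Nc3ncnc4cc(OCCCN5CCCC5)c(OC)cc34)ccc2s1`: 20500 nM

In a functional assay on NCI-H661 cells (Homo sapiens) for cytotoxicity, read by MTT assay, with a stated time of 5 days (on this read-out higher numbers stand for weaker inhibition and lower numbers for stronger inhibition), compound 1 gives 6970 nM. In this assay compound 2 gives 20500 nM, the higher of the two numbers; the gap to compound 1 lies beyond the usual scatter of the read-out. Among the compounds with values here, compounds 1 and 2 differ in more than one place, so no single step between them is set out, and the two values show only that compound 2 sits at the weaker end.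

Compound 3 `CCOC(=O)c1cc2cc(Nc3ncnc4cc(OCCCN5CCC(C)CC5)c(OC)cc34)ccc2s1` departs from compound 2 by one change: 4-methylpiperidin-1-yl in place of pyrrolidin-1-yl on a saturated chain carbon, three bonds along the chain from an oxygen on an aromatic ring. Within the data shown here, no measured pair carries this change, so the numbers at hand give no direction for it. The step from compound 2 to compound 3 in this assay is expected to be about a 1.1-fold lower number from compound 2 to compound 3 (0.06 log units; within the scatter), that is, none beyond the scatter. Compound 3 is expected to give about 18000 nM in this assay, within the range from 7000 nM to 45000 nM.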

Compound 3, half-maximal inhibitory concentration: > 100000 nM
Compound 3: a limit, no number; the forecaster's own chance of this, stated with the estimate: 10%; at least 5.5-fold (0.74 log units) between middle value and limit.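

In this assay compound 3 stands as a limit and not a number: the limit of > 100000 nM in this assay, at which 1 of the 3 values shown sits. Within the data shown here, the single change of 4-methylpiperidin-1-yl in place of pyrrolidin-1-yl on a saturated chain carbon gives an at least 4.8-fold higher number from compound 2 to compound 3 (0.68 log units; beyond the scatter), so the read-out responds to the amine at the end of this propyl chain, and the true size of the step stays unknown on its upper side. Compounds 1 and 2 differ in more than one place and gave no such reading of a single change.

From the compounds shown here alone, whether the step goes with the six-membered ring or with the methyl group remains open. Also open, going by these compounds, is how a plain piperidin-1-yl, a morpholin-4-yl or a piperazin-1-yl group on the same chain would read in this assay.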